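Amide to urea on the shared core: toxicity in UACC-62 cells

A few compounds are considered here, and "the series" means these few. Any claim that something is new, unique, unknown or untested is made for them only; others in the source may bear on it.

Measured compounds:
compound 1 `COc1cc(-c2nn(-c3cccc(NC(=O)c4cccc(C(F)(F)F)c4)c3)cc2-c2ccncc2)ccc1Cl` — > 50000 nM
compound 2 `O=C(Nc1cccc(-n2cc(-c3ccncc3)c(-c3ccc(Cl)c(O)c3)n2)c1)Nc1cc(C(F)(F)F)cc(C(F)(F)F)c1` — 8460 nM
compound 3 `O=C(Nc1cccc(-n2cc(-c3ccncc3)c(-c3ccc(Cl)c(O)c3)n2)c1)Nc1ccc(Cl)c(C(F)(F)F)c1` — 3160 nM

In a functional assay on UACC-62 cells (Homo sapiens) for inhibition, read by sulforhodamine B assay, with a stated time of 48 h (on this read-out higher numbers stand for lower toxicity in this test and lower numbers for higher toxicity in this test), compound 1 gives > 50000 nM, which is a limit of the assay and not a number. Compound 1 therefore sits at the limit of > 50000 nM in this assay, at which 1 of the 3 values shown sits. Compound 2, with a urea and a hydroxyl-bearing core, gives 8460 nM, and compound 3 gives 3160 nM. Neither differs from compound 1 in one place only, so their values are noted here without a step.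

Compound 4 `COc1cc(-c2nn(-c3cccc(NC(=O)Nc4ccc(Cl)c(Cl)c4)c3)cc2-c2ccncc2)ccc1Cl` is not yet measured. It differs from compound 1 as follows: (3,4-dichlorophenyl)amino in place of 3-(trifluoromethyl)phenyl on a carbonyl carbon. The carbonyl thus becomes part of a urea, as in compound 2 and compound 3, while the core stays that of compound 1.

The values of compound 2 and compound 3 sit well below the limit shown for compound 1, and both carry a urea. On that ground the step of an at least 8.3-fold lower number from compound 1 to compound 4 (0.92 log units; beyond the scatter) is expected to run toward higher toxicity, beyond the scatter. Compound 4 is estimated at 6000 nM, with a range from 2000 nM to 25000 nM. This expectation rests on two compounds only and on a different core; compound 4 may still report only a limit.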

Compound 4, concentration lethal to 50% of the cells: 4490 nM
Compound 4: middle estimate off by 1.3-fold (0.13 log units), on the high side, within the range that was stated.
By their numbers in this assay, from the lowest: compounds 3, 4 and 2 (each within the scatter of the next, the first and the last beyond it). At a limit, above all of these: compound 1.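

Among these compounds, at the carbonyl carbon of the shared core, replacing 3-(trifluoromethyl)phenyl with (3,4-dichlorophenyl)amino gives the first single-place step that can be read. In this assay this change brings an at least 11-fold lower number from compound 1 to compound 4 (1.04 log units; beyond the scatter), toward higher toxicity in this test. Compound 4 gives 4490 nM with no hydroxyl on its core, so in this series a measurable value with a urea does not depend on the hydroxyl-bearing core. The starting point of the step is a limit and not a number, so the step has a bound and no exact size: the limit of > 50000 nM in this assay, at which 1 of the 4 values shown sits.

The step changes two things at once: the carbonyl becomes part of a urea with a hydrogen-bond donor on the entering group, and two chlorines replace the trifluoromethyl on the aromatic ring, so the shift cannot be assigned to either change alone. On these data alone, a (3-(trifluoromethyl)phenyl)amino group on the same carbonyl would separate the two, and it remains open how a carboxylic acid, an amine or a longer chain in this place would read in this assay.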